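This account rests on a few compounds, and the source may have more. Where it says the series, first, only, none or still open, it means among the compounds named here.

Compound 1 `CC(C)(C)Cc1c(-c2cccc(F)c2F)sc(N)c1C(=O)c1ccc(Cl)cc1`: 1%
Compound 2 `COc1cccc(-c2sc(N)c(C(=O)c3ccc(Cl)cc3)c2CC(C)(C)C)c1`: 1%

The two measured compounds share one core and differ only in the aromatic group attached to it. In an assay on CHO cells for displacement of a labelled ligand from adenosine receptor A1 (Homo sapiens), read by scintillation counting, tested at 10 uM (a lower number here means less inhibition, a higher number more inhibition at the concentration tested (going by the name of the read-out)), compound 1 gives 1%, and in the same test compound 2 gives 1%. The step between them, no change at the digits printed from compound 1 to compound 2 (within the scatter), means compound 2 stands level with compound 1 at the digits shown: both sit at the bottom of the scale, with essentially no displacement of the labelled ligand at the tested concentration.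

Compound 3 `Cc1ccc(-c2sc(N)c(C(=O)c3ccc(Cl)cc3)c2CC(C)(C)C)cc1` is not yet measured. Its change from compound 2 is 4-methylphenyl in place of 3-methoxyphenyl on an aromatic carbon. For the measured compounds named here, only one measured step speaks to this kind of change, the exchange of one aromatic group for another at the same ring carbon from compound 1 to compound 2, and that step brought no change beyond the scatter. On that basis the expected step from compound 2 to compound 3 is a number 1 percentage points higher from compound 2 to compound 3 (within the scatter), with no movement beyond the scatter in either direction. Compound 3 is therefore estimated at 2%, within a range from 0% to 12%.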

Compound 3, a percentage reported as inhibition, at one concentration (the size of the read-out at that concentration, not a potency): 1%
Estimate against measurement, compound 3: 1 percentage points above; low and high end bracket the measured number.
By their numbers in this assay, from the lowest: compounds 1, 2 and 3 (each within the scatter of the next).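

In this assay, the exchange at the aromatic carbon next to the ring sulfur gives no change at the digits printed from compound 2 to compound 3 (within the scatter), and the comparison with the difluorinated compound gives no change at the digits printed from compound 1 to compound 3 (within the scatter). For the compounds shown here, this adds a new kind of change to the single step seen earlier: 3-methoxyphenyl, with its one hydrogen-bond acceptor, gives way to 4-methylphenyl, with none, and the reading still does not move, so three different aryl groups at this carbon now share the same result at the bottom of the scale. A reading this close to the floor shows only that none of these compounds displaces much labelled ligand at the tested concentration, and no separate measurement is available to explain the result.

On these data alone, what remains open is whether any group at this carbon can lift the reading off the floor, for example a phenyl ring carrying a carboxylic acid or a dimethylamino group, or a pyridine ring. As far as these compounds go, it is also open whether a group other than neopentyl on the neighbouring ring atom, such as a shorter ethyl chain, would make the aryl group matter at all.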